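This account rests on a few compounds, and the source may have more. Where it says the series, first, only, none or still open, it means among the compounds named here.

Measured so far:
compound 1 `Cc1nn(-c2ncnc3nc[nH]c23)c2c1C(C(=O)Nc1ccccc1)CC(=O)N2` — 10 nM
compound 2 `Cc1nn(-c2ncnc3nc[nH]c23)c2c1C(c1ccc(OC(C)C)cc1)CC(=O)N2` — 18 nM
compound 3 `Cc1nn(-c2ncnc3nc[nH]c23)c2c1C(OCCc1ccccc1)CC(=O)N2` — 3 nM

In a functional assay on HEK293 cells for agonist activity at G-protein coupled receptor 39 (Homo sapiens), read by scintillation proximity assay and inositol phosphate accumulation, with a stated time of 75 min, in the presence of a further agent that is not named here (a higher number here means that more compound is needed for the effect, a lower number that less compound is needed), compound 1 and compound 2 give numbers within the scatter of each other (a 1.8-fold higher number from compound 1 to compound 2 (0.26 log units; within the scatter)), while compound 3 gives a lower number (a 3.3-fold lower number from compound 1 to compound 3 (0.52 log units; beyond the scatter)). Compound 4 `Cc1nn(-c2ncnc3nc[nH]c23)c2c1C(c1ccc(F)cc1Cl)CC(=O)N2` differs from compound 1 in one place: 2-chloro-4-fluorophenyl in place of phenylcarbamoyl on a saturated ring carbon. For the measured compounds named here, the step from compound 1 to compound 2 is the closest guide, since it also puts an aryl group on that saturated ring carbon and stayed within the scatter; the move to phenethyloxy in compound 3 was the only change beyond it. For compound 4 a step of a 1.5-fold higher number from compound 1 to compound 4 (0.18 log units; within the scatter) is therefore expected, not beyond the scatter. Compound 4 is estimated at 15 nM, between 5 nM and 45 nM.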

Compound 4, half-maximal effective concentration: 9 nM
Compound 4: the middle estimate sits 1.7-fold (0.22 log units) above what was measured; the range from low to high includes it.
By their numbers in this assay, from the lowest: compound 3; then compounds 4, 1 and 2 (each within the scatter of the next).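

In this assay, 2-chloro-4-fluorophenyl, with no hydrogen-bond donor or acceptor, can stand on this saturated ring carbon in place of phenylcarbamoyl without a change beyond the scatter, a 1.1-fold lower number from compound 1 to compound 4 (0.05 log units; within the scatter). Two differently substituted phenyl groups also stay within the scatter of each other, a 2.0-fold lower number from compound 2 to compound 4 (0.30 log units; within the scatter), while the change from phenethyloxy remains beyond it, a 3.0-fold higher number from compound 3 to compound 4 (0.48 log units; beyond the scatter). No supporting evidence is available to explain these results. The compounds shown leave open how an amine, a carboxylic acid or a longer ether chain on this carbon would behave.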